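The source may hold more compounds than are shown below. What is called first, only, known or untested is meant among the compounds shown, and "the series" means these compounds.

Compound 1 `CC(C)(C)C(=O)OC1CC2(N3CCCCC3)CC(c3ccccc3)C1C(c1ccccc1)C2` gives 12000 nM in an ADME assay on L6 cells (Rattus norvegicus) for cytotoxicity, with a stated time of 72 h (on this read-out lower numbers stand for stronger inhibition and higher numbers for weaker inhibition), and compound 2 `OC1CC2(N3CCCC3)CC(c3ccccc3)C1C(c1ccccc1)C2` gives 26800 nM in this assay. For the measured compounds named here, compound 3 `CC(=O)OC1CC2(N3CCCC3)CC(c3ccccc3)C1C(c1ccccc1)C2` was run in this assay and its entry reads "not determined" (no result reported), so it stands without a single number, and no step from it can be measured. Compound 4 `CC(C)(C)C(=O)OC1CC2(N3CCCC3)CC(c3ccccc3)C1C(c1ccccc1)C2` differs from compound 3 by tert-butyl in place of methyl on a carbonyl carbon. Going by these compounds, with compound 3 lacking a number, the size and direction of the step to compound 4 in this assay cannot be judged beyond what compound 1 and compound 2 show; whether it clears the scatter is unknown. Compound 4 is expected to give about 15000 nM in this assay, within a range of 5000 nM to 45000 nM, since compound 1 gives 12000 nM and compound 2 gives 26800 nM.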

Compound 4, half-maximal inhibitory concentration: 7620 nM
Compound 4: the middle estimate sits 2.0-fold (0.29 log units) above what was measured, and the stated range covers the measured number.
By their numbers in this assay, from the lowest: compounds 4 and 1 (each within the scatter of the next); then compound 2.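

With (tert-butyl)carbonyl in place of hydrogen on the oxygen, this assay shows a 3.5-fold lower number from compound 2 to compound 4 (0.55 log units; beyond the scatter), so this ester separates from the free alcohol beyond the scatter. Pyrrolidin-1-yl in place of piperidin-1-yl, with the ester held constant, gives a 1.6-fold lower number from compound 1 to compound 4 (0.20 log units; within the scatter), which stays within the scatter. No measurement at hand accounts for either step. The step from acetyl to (tert-butyl)carbonyl cannot be read, as compound 3 has no number. Open too, going by these compounds, is how an ethyl group, a longer chain or an amine on the carbonyl carbon would read in this assay.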